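Urea series on K562: isopropyl to sec-butyl on the aryl side

This account rests on a few compounds, and the source may have more. Where it says the series, first, only, none or still open, it means among the compounds named here.

Compound 3 `CNC(=O)Nc1ccc(C(C)C)cc1` gives 198000 nM in a functional assay on K562 cells (Homo sapiens) (a higher number here means a weaker inhibitor, a lower number a stronger inhibitor), the highest of the three numbers measured, though compound 2 `CCCNC(=O)Nc1ccc(C(C)CC)cc1` at 106000 nM and compound 1 `CCNC(=O)Nc1ccc(C(C)CC)cc1` at 101000 nM both lie within the scatter of it. Compound 4 `CCC(C)c1ccc(NC(=O)NC)cc1` differs from compound 3 by methyl in place of hydrogen on a saturated chain carbon, two bonds along the chain from an aromatic carbon. Going by the values given here, no measured step touches this part of the shared core; the only step on record, a 1.0-fold higher number from compound 1 to compound 2 (0.02 log units; within the scatter), sits on the urea side and stayed within the scatter. Compounds 1 and 3, which differ in two places including this one, also agree within the scatter. A step of a 1.4-fold lower number from compound 3 to compound 4 (0.15 log units; within the scatter) in this assay is therefore expected, nothing beyond the scatter. Compound 4 is estimated at 140000 nM, with a range of 60000 nM to 320000 nM.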

Compound 4, half-maximal inhibitory concentration: 142000 nM
Beside the measured number, compound 4's estimate is 1.0-fold (0.01 log units) below it, within the range that was stated.
By their numbers in this assay, from the lowest: compounds 1, 2, 4 and 3 (each within the scatter of the next).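

Isopropyl to sec-butyl, methyl in place of hydrogen on a saturated chain carbon two bonds along the chain from an aromatic carbon, now has its own measured step in this assay, and it stays within the scatter: a 1.4-fold lower number from compound 3 to compound 4 (0.14 log units; within the scatter). Changes on the urea side also stay within the scatter, with a 1.3-fold higher number from compound 2 to compound 4 (0.13 log units; within the scatter) and a 1.4-fold higher number from compound 1 to compound 4 (0.15 log units; within the scatter). The same change on the two cores gives steps that agree: the same change on two cores in this assay, a 1.0-fold higher number (0.02 log units; within the scatter) from compound 1 to compound 2 and a 1.4-fold lower number (0.14 log units; within the scatter) from compound 3 to compound 4, 1.5-fold (0.17 log units) apart, within the scatter of two such steps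

From the compounds shown here alone, whether a longer chain or a carboxylic acid at this position would move the number beyond the scatter stays open.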